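Moving a halogen on the amide-bound phenyl ring

The source may report more compounds than this note shows. Statements on the series, on what has been measured and on what is new or still open speak of the compounds shown alone.

compound 1 `O=C(O)CCc1nnc(C(=O)Nc2ccc(OCc3ccccc3)cc2)s1`: 17900 nM
compound 2 `O=C(O)CCc1ccc(OCc2nnc(C(=O)Nc3ccccc3F)s2)cc1`: 580 nM

Of the compounds shown here, two have been measured in a functional assay on CHO cells for agonist activity at Free fatty acid receptor 1 (Homo sapiens), read by calcium flux; a lower number here means that less compound is needed, a higher number that more compound is needed for the effect. Compound 1 gives 17900 nM. Compound 2 gives 580 nM, the lower of the two numbers, and the gap between them lies beyond the usual scatter. The two compounds differ in several places at once, so nothing can be said about which part of the structure carries that difference.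

Compound 3 `O=C(O)CCc1ccc(OCc2nnc(C(=O)Nc3ccc(Cl)cc3)s2)cc1` keeps the whole of compound 2 except for one change: 4-chlorophenyl in place of 2-fluorophenyl on an amide-type nitrogen. Going by the values given here, no measured pair in this set shows a change of this kind, so there is no step to lean on. Without such a step, the expectation is that compound 3 stays close to compound 2, with an estimated change from a 1.2-fold higher number from compound 2 to compound 3 (0.08 log units; within the scatter) that may not exceed the scatter. Compound 3 is therefore estimated at 700 nM, with a range from 250 nM to 2000 nM.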

Compound 3, half-maximal effective concentration: 3690 nM
Estimate against measurement, compound 3: 5.3-fold (0.72 log units) below, outside the stated range (above it).
By their numbers in this assay, from the lowest: compound 2; then compound 3; then compound 1.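

In this assay, going by these compounds alone, 4-chlorophenyl in place of 2-fluorophenyl on the amide-type nitrogen gives a 6.4-fold higher number from compound 2 to compound 3 (0.80 log units; beyond the scatter) and so shows, for the first time in this set, that this one group moves the number while the rest of the structure stays fixed. Both groups count the same heavy atoms and the same single six-membered aromatic ring, so those counts do not separate them. Nothing measured here bears on why the number moves.

The step changes the halogen and its place on the ring together, so the part played by each remains unresolved. A phenyl ring carrying no halogen, or one carrying a methoxy group or a trifluoromethyl group, would show how far this position tolerates other groups.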